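Butylamide to Cyclohexylamide on a Shared Dimethoxy Core

A few compounds are considered here, and "the series" means these few. Any claim that something is new, unique, unknown or untested is made for them only; others in the source may bear on it.

Compound 1, `COc1cc2c(cc1OC)C(CC(=O)O)CC2`: 20.4%
Compound 2, `CCN(CC)C(=O)CC1CCc2cc(OC)c(OC)cc21`: 31.5%
Compound 3, `CCCCNC(=O)CC1CCc2cc(OC)c(OC)cc21`: 24.1%

In a functional assay on the whole organism (strain Wistar) for inhibition, with Rattus norvegicus as the target, read by paw edema, with stated times of 60 min and 6 h, at a dose of 100 mg/kg by the oral route (a higher number here means more inhibition at the dose given (going by the name of the read-out), a lower number less inhibition), compound 3 holds the second highest of the three numbers; compound 1 sits nearest and compound 2 furthest, with both gaps inside the scatter. Compound 4 is `COc1cc2c(cc1OC)C(CC(=O)NC1CCCCC1)CC2`, differing from compound 3 by cyclohexyl in place of butyl on an amide-type nitrogen. Within the data shown here, the steps that bear on this change are a number 7.4 percentage points lower from compound 2 to compound 3 (within the scatter) and a number 3.7 percentage points higher from compound 1 to compound 3 (within the scatter), both within the scatter, so variation at the amide-type nitrogen has so far moved the read-out little. The step of a number 1.9 percentage points higher from compound 3 to compound 4 (within the scatter) is therefore expected to stay within the scatter, with no clear direction. Compound 4 is estimated at 26%, with a range from 12% to 40%.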

Compound 4, a percentage reported as inhibition, in the whole organism at one dose (the size of the read-out at that dose, not a potency): 48.2%
For compound 4 the middle estimate is 22.2 percentage points below the measured one, outside the stated range (above it).
By their numbers in this assay, from the lowest: compounds 1, 3 and 2 (each within the scatter of the next, the first and the last beyond it); then compound 4.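

In this assay, cyclohexyl in place of butyl on an amide-type nitrogen gives a number 24.1 percentage points higher from compound 3 to compound 4 (beyond the scatter), so this position can carry a step beyond the scatter, which the change from diethylamino to butylamino did not show. Compound 4 also stands clear of the other two compounds, with a number 16.7 percentage points higher from compound 2 to compound 4 (beyond the scatter) and a number 27.8 percentage points higher from compound 1 to compound 4 (beyond the scatter). Nothing measured here accounts for this gain. From the compounds shown here alone, whether it follows from the ring or from the added carbons stays open: a hexyl chain or a cyclopentyl group on the same nitrogen would separate the two.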